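Methylsulfamoyl in place of the acylamino group: compound 4

The compounds below may be only part of what the source reports. "The series", "measured", "known", "first", "only" and "open" are said of these compounds alone.

Three compounds share one core and differ only in the group on the saturated ring. Compound 1 `COCCNC(=O)[C@@H]1CC[C@@H](Nc2ncc3c(Br)nn(-c4ccc5ncccc5c4)c3n2)C1` gives 5 nM in an assay on isolated protein for inhibition of eIF-2-alpha kinase GCN2 (Homo sapiens); on this read-out lower numbers stand for stronger inhibition and higher numbers for weaker inhibition. Compound 2 `COCCC(=O)N[C@@H]1CC[C@@H](Nc2ncc3c(Br)nn(-c4ccc5ncccc5c4)c3n2)C1` gives 74 nM in this assay, and compound 3 `COCCNC(=O)[C@H]1CC[C@@H](Nc2ncc3c(Br)nn(-c4ccc5ncccc5c4)c3n2)CC1` gives 211 nM. Among the measured compounds shown here, compound 2 therefore holds the second highest of the three numbers: its number is lower than that of compound 3, and the one single-point step that touches it, a 15-fold higher number from compound 1 to compound 2 (1.17 log units; beyond the scatter), shows that swapping the (2-methoxyethyl)carbamoyl group for the ((2-methoxyethyl)carbonyl)amino group weakened inhibition strongly.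

Compound 4 `CNS(=O)(=O)[C@@H]1CC[C@@H](Nc2ncc3c(Br)nn(-c4ccc5ncccc5c4)c3n2)C1` is not yet measured. The change is methylsulfamoyl in place of ((2-methoxyethyl)carbonyl)amino on a saturated ring carbon. For the measured compounds named here, only the step from compound 1 to compound 2 bears on it, and only loosely: it shows that the group on this ring carbon matters a great deal, and that a group joined to the ring through its own atom, as in compound 1, gave the lowest number of the three. Going by the values given here, no measured compound carries a methylsulfamoyl group, so the direction rests on that single comparison. The step of a 2.5-fold lower number from compound 2 to compound 4 (0.39 log units; beyond the scatter) is expected to run toward a lower number in this assay, of moderate size. Compound 4 is estimated at 30 nM, with a range from 5 nM to 180 nM.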

Compound 4, half-maximal inhibitory concentration: 43 nM
Estimate against measurement, compound 4: 1.4-fold (0.16 log units) below; the range from low to high includes it.
By their numbers in this assay, from the lowest: compound 1; then compounds 4 and 2 (each within the scatter of the next); then compound 3.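

In this assay, the methylsulfamoyl and ((2-methoxyethyl)carbonyl)amino groups cannot be told apart on this saturated ring carbon. The change gives a 1.7-fold lower number from compound 2 to compound 4 (0.24 log units; within the scatter), so a group of 5 heavy atoms containing sulfur and a group of 7 heavy atoms with a carbonyl read alike here. Against the (2-methoxyethyl)carbamoyl group, the same methylsulfamoyl group gives an 8.6-fold higher number from compound 1 to compound 4 (0.93 log units; beyond the scatter), so on this five-membered ring compound 1 now stands apart from two different replacements rather than one, and no information at hand accounts for either step.

The compounds shown leave open whether the low number of compound 1 depends on the carbamoyl link or on the 2-methoxyethyl chain, as the methylsulfamoyl group of compound 4 differs from it in both. A methylcarbamoyl group or a (2-methoxyethyl)sulfamoyl group on this ring carbon would separate the two, and a carboxylic acid or a primary amine there would show how far the read-out at this position extends beyond these neutral chains.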